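This account rests on a few compounds, and the source may have more. Where it says the series, first, only, none or still open, it means among the compounds named here.

Measured so far in a functional assay on MDA-MB-231 cells (Homo sapiens) for antiproliferative activity, read by MTT assay, with a stated time of 48 h; on this read-out higher numbers stand for weaker inhibition and lower numbers for stronger inhibition:
compound 1 `COc1ccc(N(C)c2ccnc(Cl)n2)cc1`: 2820 nM
compound 2 `COc1ccc(N(C)c2ccnc(Cl)n2)cc1Cl`: 1380 nM

Compound 2 holds the lower of the two numbers, with a 2.0-fold lower number from compound 1 to compound 2 (0.31 log units; beyond the scatter). That modest step came with chloro in place of hydrogen on an aromatic carbon. Compound 3 `COc1ccc(N(C)c2ccnc(Cl)n2)cc1[N+](=O)[O-]` is still unmeasured and carries nitro in place of chloro on an aromatic carbon, ortho to a methoxy group: nitro in place of chloro on an aromatic carbon. Going by the values given here, only that one step bears on this change, and it shows nothing about nitro itself. No shift beyond the scatter is therefore expected, in either direction. The estimated change is a 1.1-fold higher number from compound 2 to compound 3 (0.04 log units; within the scatter). Compound 3 is expected at 1500 nM, within a range of 500 nM to 4500 nM.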

Compound 3, half-maximal inhibitory concentration: 8120 nM
Beside the measured number, compound 3's estimate is 5.4-fold (0.73 log units) below it; the whole stated range lies below it.
By their numbers in this assay, from the lowest: compound 2; then compound 1; then compound 3.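

On the aromatic carbon ortho to a methoxy group, the outcome in this assay depends on which group sits there, since nitro in place of chloro gives a 5.9-fold higher number from compound 2 to compound 3 (0.77 log units; beyond the scatter) and nitro in place of hydrogen gives a 2.9-fold higher number from compound 1 to compound 3 (0.46 log units; beyond the scatter). Chloro lowered the number relative to hydrogen while nitro raised it, so substitution at this carbon can move the number either way. Nothing available here accounts for this difference between chloro and nitro. Still open, on these data alone, is where an amine or a carboxylic acid on this carbon would fall relative to compound 2 and compound 3. Also open, as far as these compounds go, is whether hydrogen, chloro and nitro keep this order on other carbons of the ring.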